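The source may hold more compounds than are shown below. What is called first, only, known or untested is meant among the compounds shown, and "the series" means these compounds.

Measured in a functional assay on HL-60 cells (Homo sapiens) for cytotoxicity, read by WST assay, with a stated time of 48 h; on this read-out lower numbers stand for an effect already at smaller amounts and higher numbers for an effect only at larger amounts of compound:

- compound 1 `O=C1OC[C@H](Cc2ccccc2)[C@H]1Cc1ccc(Cl)cc1`: 36000 nM
- compound 2 `O=C1OC[C@H](Cc2ccccc2O)[C@H]1Cc1ccc(Cl)c(Cl)c1`: 33000 nM
- compound 3 `CCOc1ccccc1C[C@H]1COC(=O)[C@@H]1Cc1ccc(Cl)c(Cl)c1`: 15000 nM

Compound 2 and compound 1 lie within the scatter of each other, at the upper end of this small set. Compound 3 lies lower, with a 2.2-fold lower number from compound 2 to compound 3 (0.34 log units; beyond the scatter).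

The next compound to be tested is compound 4 `Cc1cccc(C[C@H]2COC(=O)[C@@H]2Cc2ccc(Cl)c(Cl)c2)c1`. It has 3-methylphenyl in place of 2-hydroxyphenyl on a saturated chain carbon bound to a saturated ring carbon.

Going by the values given here, only one measured step touches the group that leaves. That step, a 2.2-fold lower number from compound 2 to compound 3 (0.34 log units; beyond the scatter), replaces hydrogen with ethyl on an oxygen on an aromatic ring and is modest. Like compound 4, compound 3, at 15000 nM, no longer has that hydrogen, but it keeps the oxygen and differs in its added group. Compound 1 also has no hydroxy group, but it carries one chlorine fewer, so it does not isolate the change. Among the compounds with values here, no measured step covers a 3-methylphenyl group.

In this assay, a small move to a lower number is therefore expected, no larger than the modest step and possibly within the scatter. The estimated change is a 1.5-fold lower number from compound 2 to compound 4 (0.18 log units; within the scatter). Compound 4 is expected at 22000 nM, with an estimated range from 10000 nM to 45000 nM.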

Compound 4, half-maximal effective concentration: 22000 nM
Beside the measured number, compound 4's estimate shows no gap at the digits printed, and the stated range covers the measured number.
By their numbers in this assay, from the lowest: compounds 3, 4, 2 and 1 (each within the scatter of the next, the first and the last beyond it).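

In this assay, the 3-methylphenyl group takes the place of 2-hydroxyphenyl on a saturated chain carbon bound to a saturated ring carbon, giving a 1.5-fold lower number from compound 2 to compound 4 (0.18 log units; within the scatter). The earlier compounds shown here showed only a change made on the hydroxy oxygen, which stayed in the molecule, whereas this result shows that the ring at this place can carry neither a hydrogen-bond donor nor a hydrogen-bond acceptor, and have a methyl group in a different ring position, with no change in the number that can be told from the usual scatter. Going by these compounds alone, nothing available explains why the number holds across this swap, and the single step cannot separate the loss of the hydroxy group from the arrival of the methyl group.

The compounds shown leave open how an unsubstituted phenyl group would read at this place with both chlorines of compound 2 kept, which would isolate those two parts of the change. They also leave open whether a ring bearing an amine or a carboxylic acid would move the number, as neither group is among these compounds.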